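Methoxy for tert-Butyl on the Benzyl Group

The compounds below may be only part of what the source reports. "The series", "measured", "known", "first", "only" and "open" are said of these compounds alone.

Compound 1 `CC(C)(C)c1ccc(CNCCCNS(=O)(=O)c2cc(C(F)(F)F)cc(C(F)(F)F)c2)cc1`: 2000 nM
Compound 2 `O=S(=O)(NCCCNCc1ccc(Cl)c(C(F)(F)F)c1)c1cc(C(F)(F)F)cc(C(F)(F)F)c1`: 11000 nM
Compound 3 `O=S(=O)(NCCCNCc1ccccc1)c1cc(C(F)(F)F)cc(C(F)(F)F)c1`: 15000 nM

In a functional assay on HT-29 cells (Homo sapiens) for inhibition, read by MTT assay, with a stated time of 72 h (on this read-out lower numbers stand for stronger inhibition of growth and higher numbers for weaker inhibition of growth), compound 1 stands lowest of the three measured numbers, with 2000 nM. Compound 4 `COc1ccc(CNCCCNS(=O)(=O)c2cc(C(F)(F)F)cc(C(F)(F)F)c2)cc1` differs from compound 1 by methoxy in place of tert-butyl on an aromatic carbon. Among the measured compounds shown here, two measured steps bear on this change: a 7.5-fold higher number from compound 1 to compound 3 (0.88 log units; beyond the scatter) and a 5.5-fold higher number from compound 1 to compound 2 (0.74 log units; beyond the scatter). Both replace or remove the tert-butyl of compound 1 and both raise the number by a modest amount. A methoxy is neither the tert-butyl of compound 1 nor the bare hydrogen of compound 3, so a rise of similar or somewhat smaller size is expected, estimated as a 4.0-fold higher number from compound 1 to compound 4 (0.60 log units; beyond the scatter). Compound 4 is therefore expected to give 8000 nM, within a range of 3000 nM to 20000 nM.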

Compound 4, concentration for 50% growth inhibition: 2900 nM
Beside the measured number, compound 4's estimate is 2.8-fold (0.44 log units) above it; measured number outside the range, below it.
By their numbers in this assay, from the lowest: compounds 1 and 4 (each within the scatter of the next); then compounds 2 and 3 (each within the scatter of the next).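

In this assay, methoxy can take the place of tert-butyl on this aromatic carbon with no change beyond the scatter: a 1.5-fold higher number from compound 1 to compound 4 (0.16 log units; within the scatter). The gain over the unsubstituted benzyl group is kept, with a 5.2-fold lower number from compound 3 to compound 4 (0.71 log units; beyond the scatter), and the 4-methoxyphenyl group also compares well with the 4-chloro-3-(trifluoromethyl)phenyl group, with a 3.8-fold lower number from compound 2 to compound 4 (0.58 log units; beyond the scatter). No evidence is available to explain these differences. Going by these compounds, whether a hydroxyl or an amine on the same carbon would give a similar number remains open, as does the effect of a longer chain between the two nitrogens.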